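Lengthening the ester chain of compound 2

The compounds below may be only part of what the source reports. "The series", "measured", "known", "first", "only" and "open" are said of these compounds alone.

Within the data shown here, compound 1, `O=C(CCCCCSc1ccccc1)c1ncc(-c2ccccn2)o1`, is one of two compounds measured in an assay for inhibition of Fatty-acid amide hydrolase 1 (Rattus norvegicus); on this read-out higher numbers stand for weaker inhibition and lower numbers for stronger inhibition. In this assay compound 1 gives 3 nM. Compound 2, `COC(=O)CCC(=O)c1ncc(-c2ccccn2)o1`, carries a much shorter chain ending in an ester. For compound 2 this assay reports only a limit, > 100000 nM. Compound 2 thus sits at the limit of > 100000 nM in this assay, at which 1 of the 2 values shown sits, and no number for it is known, so its distance from compound 1 cannot be stated beyond the fact that compound 1 has a measured value where compound 2 does not. Compound 3, `COC(=O)CCCCC(=O)c1ncc(-c2ccccn2)o1`, has not yet been measured in this assay. It differs from compound 2 in one place: 2-(methoxycarbonyl)ethyl in place of methoxycarbonyl on a saturated chain carbon, two bonds along the chain from a carbonyl carbon. Among the measured compounds shown here, no step between two measured compounds is available to scale this change. Compound 1 shows that a long chain on the shared core can reach strong inhibition, whereas compound 2 with its short ester chain gives no number, so some gain is expected for compound 3 from the added chain length, though likely far short of compound 1. The estimated value for compound 3 is 40000 nM, within 5000 nM to 150000 nM. This corresponds to an expected step of an at least 2.5-fold lower number from compound 2 to compound 3 (0.39 log units; beyond the scatter).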

Compound 3, inhibition constant: 1800 nM
Compound 3: middle estimate off by 22-fold (1.35 log units), on the high side; the whole stated range lies above it.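

In this assay, 2-(methoxycarbonyl)ethyl in place of methoxycarbonyl keeps the ester at the end of the chain and changes only the chain length, and this alone gives an at least 55-fold lower number from compound 2 to compound 3 (1.74 log units; beyond the scatter), so this position responds strongly to the length of the chain even without the phenylsulfanyl end. The size of that step is only a bound and not an exact figure, as compound 2 has a limit and no number: the limit of > 100000 nM in this assay, at which 1 of the 3 values shown sits. With the chain end changed, methoxycarbonyl in place of (phenylsulfanyl)methyl goes with a 600-fold higher number from compound 1 to compound 3 (2.78 log units; beyond the scatter), which shows that the group at the end of the chain also matters a great deal and that an ester-ended chain remains far from the strength of compound 1.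

From the compounds shown here alone, it remains open whether a longer chain still ending in the methyl ester would lower the number further, and how a carboxylic acid at the chain end would compare with the ester. The compounds shown also do not divide the gap to compound 1 between the phenyl ring and the sulfur atom, a question that a plain alkyl chain ending or a benzyl group could address.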